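Swapping Trifluoromethyl for Fluoro in Compound 3

The source may hold more compounds than are shown below. What is called first, only, known or untested is meant among the compounds shown, and "the series" means these compounds.

Going by the values given here, in a functional assay on the whole organism with Scenedesmus acutus as the target, read by spectrophotometry (on this read-out higher numbers stand for weaker inhibition and lower numbers for stronger inhibition), compound 3 (`O=c1c2c(sn1-c1ccc(Cl)cc1C(F)(F)F)CCCC2`) gives 44700 nM, the highest number of the three measured so far. Compound 2 (`O=c1c2c(sn1-c1ccc(Cl)cc1)CCCC2`) gives 16600 nM, and compound 1 (`O=c1c2c(sn1-c1cc(OC3CCCC3)c(Cl)cc1F)CCCC2`), which also carries fluoro, gives 9550 nM. The unmeasured compound 4 (`O=c1c2c(sn1-c1ccc(Cl)cc1F)CCCC2`) has fluoro in place of trifluoromethyl on an aromatic carbon. Among the compounds with values here, the one measured step that bears on this is a 2.7-fold higher number from compound 2 to compound 3 (0.43 log units; beyond the scatter), a modest rise beyond the scatter when trifluoromethyl replaces hydrogen on an aromatic carbon. Losing trifluoromethyl is therefore expected to reverse much of that rise, giving a modest step to a lower number, a 2.8-fold lower number from compound 3 to compound 4 (0.45 log units; beyond the scatter). The estimated value for compound 4 is 16000 nM, with an expected range from 7500 nM to 34000 nM.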

Compound 4, half-maximal inhibitory concentration: 20400 nM
For compound 4 the middle estimate is 1.3-fold (0.11 log units) below the measured one, and the stated range covers the measured number.
By their numbers in this assay, from the lowest: compounds 1, 2 and 4 (each within the scatter of the next, the first and the last beyond it); then compound 3.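

In this assay, fluoro on this aromatic carbon reads level with hydrogen (a 1.2-fold higher number from compound 2 to compound 4 (0.09 log units; within the scatter)), while trifluoromethyl stands apart from fluoro (a 2.2-fold lower number from compound 3 to compound 4 (0.34 log units; beyond the scatter)), so among these three groups only trifluoromethyl shifts the number here. A second place on the ring also counts, as the change to hydrogen in place of cyclopentyloxy shows (a 2.1-fold higher number from compound 1 to compound 4 (0.33 log units; beyond the scatter)). No evidence is available to explain either difference. From the compounds shown here alone, whether a methyl or methoxy group at the first place would read with fluoro or with trifluoromethyl stays open. So does whether a shorter alkoxy chain could stand in for cyclopentyloxy.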